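The source may report more compounds than this note shows. Statements on the series, on what has been measured and on what is new or still open speak of the compounds shown alone.

In an ADME assay on microsomes from liver (Rattus norvegicus) for metabolic stability (a lower number here means that the compound disappears faster, a higher number that the compound lasts longer), compound 1 `CCn1ncc2c(F)cc(-c3ccc(C(CC)(CC)c4nncn4C)c(=O)[nH]3)cc21` gives > 3 h, which is a limit of the assay and not a number. Compound 2 `CC(C)C(c1nnc[nH]1)c1ccc(-c2ccc3cccc(F)c3c2)[nH]c1=O` gives 0.552 h, the only exact figure so far. Compound 3 `CC(C)C(/C=C1/CCNC1=O)c1ccc(-c2ccc3cccc(F)c3c2)[nH]c1=O` differs from compound 2 in one place, a saturated chain carbon bound to an aromatic carbon and a saturated chain carbon: a group of 7 heavy atoms (5 carbon, 1 nitrogen, 1 oxygen; one five-membered non-aromatic ring with 1 hetero atom) in place of a group of 5 heavy atoms (2 carbon, 3 nitrogen; one five-membered aromatic ring with 3 hetero atoms), on a saturated chain carbon bound to an aromatic carbon and a saturated chain carbon. Among the compounds with values here, no measured pair tests such a swap. No change beyond the usual scatter is expected in this assay. The estimated change is a 1.2-fold lower number from compound 2 to compound 3 (0.09 log units; within the scatter). Compound 3 is expected to give 0.45 h, with an estimated range of 0.15 h to 1.3 h.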

Compound 3, half-life: 0.06 h
For compound 3 the middle estimate is 7.5-fold (0.88 log units) above the measured one, and the stated range ends above it.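

At the saturated chain carbon bound to an aromatic carbon and a saturated chain carbon, the group is not a silent choice in this assay: replacing 4H-1,2,4-triazol-3-yl with the five-membered non-aromatic ring gives a 9.2-fold lower number from compound 2 to compound 3 (0.96 log units; beyond the scatter). Within the data shown here, this is the first measured swap at this place, and the compound with the new ring disappears faster. Nothing measured here accounts for the drop.

From the compounds shown here alone, this reading rests on a single pair, so it remains open how an amine or a carboxylic acid would fare on this carbon. Also open, going by these compounds, is whether the same swap would matter as much on the core of compound 1.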